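A few compounds are considered here, and "the series" means these few. Any claim that something is new, unique, unknown or untested is made for them only; others in the source may bear on it.

Among the measured compounds shown here, in an ADME assay on CCRF-CEM cells (Homo sapiens) for cytotoxicity, with a stated time of 72 h (on this read-out higher numbers stand for weaker inhibition and lower numbers for stronger inhibition), compound 3 `COc1ccc(-c2nc3sc(Cc4ccc(Cl)cc4)nn3c2Br)cc1` gives 58000 nM, the only real number among the three measured compounds. Compound 1 `Fc1ccc(-c2nc3sc(Cc4ccc(Cl)cc4)nn3c2Br)cc1` reaches only a limit of this assay, > 250000 nM. Compound 2 `Clc1ccc(Cc2nn3c(Br)c(-c4ccc(Cl)cc4)nc3s2)cc1` likewise reaches only a limit, > 250000 nM, so the limit of > 250000 nM in this assay, at which 2 of the 3 values shown sit, bounds two of the three values. Compound 4 `Clc1ccc(Cc2nn3c(Br)c(-c4ccccc4)nc3s2)cc1` differs from compound 3 in one place: hydrogen in place of methoxy on an aromatic carbon. For the measured compounds named here, two measured steps bear on this change, both running toward methoxy: an at least 4.3-fold lower number from compound 1 to compound 3 (0.63 log units; beyond the scatter) and an at least 4.3-fold lower number from compound 2 to compound 3 (0.63 log units; beyond the scatter). Removing the methoxy again is therefore expected to run the other way, giving a 3.4-fold higher number from compound 3 to compound 4 (0.54 log units; beyond the scatter), so compound 4 is estimated at 200000 nM, within a range from 60000 nM to 500000 nM, with a good chance of returning to a limit.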

Compound 4, half-maximal inhibitory concentration: > 250000 nM
Compound 4: a limit, no number; the forecaster's own chance of this, stated with the estimate: 55%; middle value at least 1.2-fold (0.09 log units) from the limit.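

Replacing 4-methoxyphenyl with phenyl gives an at least 4.3-fold higher number from compound 3 to compound 4 (0.63 log units; beyond the scatter) in this assay. Among the compounds shown here, the earlier compounds set methoxy only against fluoro and chloro, whereas this step shows that hydrogen at this place also gives no readable number, leaving methoxy the only group of the four with one. The steps among compounds 1, 2 and 4 cannot be read, because all three values are limits, not numbers: the limit of > 250000 nM in this assay, at which 3 of the 4 values shown sit.

From the compounds shown here alone, whether an ethoxy group, a hydroxyl or an amine at this place would also give a lower number stays open. So does how much weaker compounds 1, 2 and 4 really are.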